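From 4-chlorobenzyl to 4-methylbenzyl in the series

The source may report more compounds than this note shows. Statements on the series, on what has been measured and on what is new or still open speak of the compounds shown alone.

In a functional assay on DU-145 cells (Homo sapiens) for inhibition, read by trypan blue exclusion, with a stated time of 96 h (a higher number here means a weaker inhibitor of growth, a lower number a stronger inhibitor of growth), compound 1 (`COc1ccccc1/C=C(/SCc1ccc(Cl)cc1)C(=O)c1ccc(Cl)cc1`) gives 1000 nM and compound 2 (`O=C(/C(=C\c1ccc(Br)cc1)SCc1ccc(Cl)cc1)c1ccc(Cl)cc1`) gives 1000 nM so compound 2 stands level with compound 1. Compound 3 (`Cc1ccc(CS/C(=C/c2ccc(Br)cc2)C(=O)c2ccc(Cl)cc2)cc1`) differs from compound 2 only in the 4-chlorobenzyl group, which becomes 4-methylbenzyl: methyl in place of chloro on an aromatic carbon, para to a large group (methyl in place of chloro on an aromatic carbon). Going by the values given here, the one measured step, no change at the digits printed from compound 1 to compound 2 (within the scatter) for 4-bromophenyl in place of 2-methoxyphenyl, lies at a different place in the molecule and bears only indirectly. Among the compounds with values here, no measured step touches the 4-chlorobenzyl group. In this assay a change no larger than the scatter is therefore expected, with neither direction favoured. The estimated step is no change at the digits printed from compound 2 to compound 3 (within the scatter) on this reading. For compound 3 the expected value is 1000 nM with an estimated range from 450 nM to 2500 nM as a wide allowance.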

Compound 3, concentration for 50% growth inhibition: 10000 nM
The estimate for compound 3 lay 10-fold (1.00 log units) below the measured number; measured number above the stated range.
By their numbers in this assay, from the lowest: compounds 1 and 2 (each within the scatter of the next); then compound 3.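

In this assay the 4-chlorobenzyl group proves to be a position where the number can move: methyl in place of chloro on this aromatic carbon, para to a large group, gives a 10-fold higher number from compound 2 to compound 3 (1.00 log units; beyond the scatter) and so separates compound 3 from compound 2 beyond the scatter. The exchange involves one heavy atom, with no ring and no hydrogen-bond donor or acceptor entering or leaving, so even a change this small at this position is enough to shift the reading. Nothing measured here accounts for the step.

From the compounds shown here alone, whether the step carries over when the 4-bromophenyl group is replaced by the 2-methoxyphenyl group of compound 1 remains open. Also open, going by these compounds, is how an amine, a nitrile or a longer chain on the same aromatic carbon would read.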